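The compounds below may be only part of what the source reports. "The series", "measured", "known", "first", "only" and "open" are said of these compounds alone.

The measured compounds:

Compound 1 `O=C(O)CCNC(=O)c1ccc2c(c1)C(=O)N(CCC1CCNCC1)C2` gives 25 nM in a functional assay on the whole organism for inhibition, with Homo sapiens as the target; a higher number here means a weaker inhibitor, a lower number a stronger inhibitor.
Compound 2 `CCCCS(=O)(=O)N[C@@H](CNC(=O)c1cc2c(s1)CCN(CCC1CCNCC1)C2=O)C(=O)O` gives 8 nM in this assay.
Compound 3 `CCCCS(=O)(=O)N[C@@H](CNC(=O)c1csc2c1C(=O)N(CCC1CCNCC1)CC2)C(=O)O` gives 33000 nM in this assay.

Compound 2 has the lowest number of the three and is therefore the strongest inhibitor among them. Compound 1 comes nearest, with a higher number that lies beyond the usual scatter, and compound 3 lies furthest away, with a far higher number.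

Compound 4 `O=C(NCc1ccccc1)N[C@@H](CNC(=O)c1cc2c(s1)CCN(CCC1CCNCC1)C2=O)C(=O)O` has not yet been measured. It differs from compound 2 in one place: benzylcarbamoyl in place of butylsulfonyl on an amine nitrogen. The rest of the molecule, including the acid and the basic ring, is kept unchanged. Among the compounds with values here, no pair of measured compounds shows this exact exchange, so its effect cannot be read off a known step; it can only be estimated. The expectation is a modest move toward a higher number, that is a somewhat weaker inhibitor, of a size close to the scatter or slightly beyond it. For compound 4 the estimated value is 20 nM, with a range from 5 nM to 80 nM, which corresponds to an expected step of a 2.5-fold higher number from compound 2 to compound 4 (0.40 log units; beyond the scatter).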

Compound 4, half-maximal inhibitory concentration: 25 nM
Estimate against measurement, compound 4: 1.3-fold (0.10 log units) below; the range from low to high includes it.
By their numbers in this assay, from the lowest: compound 2; then compounds 1 and 4 (each within the scatter of the next); then compound 3.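

In this assay, within the data shown here, the exchange on this amine nitrogen gives a 3.1-fold higher number from compound 2 to compound 4 (0.49 log units; beyond the scatter), a modest step and the first direct reading of a change at this position. The entering benzylcarbamoyl brings a six-membered aromatic ring and a hydrogen-bond donor that butylsulfonyl lacks, yet the number moves only modestly, so for this pair the position accepts two quite different groups. No measurement at hand explains the size of this step.

The exchange alters both the linking unit and the group at its far end, so the compounds shown cannot tell which of the two accounts for the step; butylcarbamoyl or benzylsulfonyl on the same nitrogen would separate them. Going by these compounds, how a free amine at this place would compare also remains open.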